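Swapping methylamino for 2,6-dimethylmorpholin-4-yl

The compounds below may be only part of what the source reports. "The series", "measured", "known", "first", "only" and "open" are said of these compounds alone.

- Compound 1 `O=C(CCc1ccc(NC(=O)Nc2ccc(Cl)c(C(F)(F)F)c2)cc1)NC1CCC1` gives 24000 nM
- Compound 2 `CNC(=O)CCc1ccc(NC(=O)Nc2ccc(Cl)c(C(F)(F)F)c2)cc1` gives 20400 nM

Both values were measured in a functional assay on MX1 cells (Homo sapiens) for inhibition, read by MTT assay, with a stated time of 120 h (on this read-out lower numbers stand for stronger inhibition and higher numbers for weaker inhibition), and they are all that is known so far. Among the compounds with values here, the only measured step is a 1.2-fold lower number from compound 1 to compound 2 (0.07 log units; within the scatter) and so the two numbers stand level, with neither ahead. Within the data shown here, compound 2 therefore shares its place with its one neighbour rather than leading it.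

Compound 3 `CC1CN(C(=O)CCc2ccc(NC(=O)Nc3ccc(Cl)c(C(F)(F)F)c3)cc2)CC(C)O1` carries 2,6-dimethylmorpholin-4-yl in place of methylamino on a carbonyl carbon. Among the measured compounds shown here, the earlier swap of cyclobutyl for methyl on an amide-type nitrogen is the only measured evidence that bears on this change. For the measured compounds named here, it is a loose guide, since no measured compound carries 2,6-dimethylmorpholin-4-yl and the entering group is much larger. Resting on a 1.2-fold lower number from compound 1 to compound 2 (0.07 log units; within the scatter) as the only size seen so far, no step beyond the scatter is expected in this assay and neither direction can be favoured. The expected step is a 1.0-fold lower number from compound 2 to compound 3 (0.01 log units; within the scatter) with wide margins on either side. Compound 3 is estimated at 20000 nM (expected range 8000 nM to 45000 nM).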

Compound 3, half-maximal inhibitory concentration: > 50000 nM
Compound 3: a limit, no number; the forecaster's own chance of this, stated with the estimate: 15%; middle value at least 2.5-fold (0.39 log units) away from the limit.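

In this assay compound 3 gives > 50000 nM, which is a limit of the assay and not a number. Even so, it shows that the group on this carbonyl carbon can move the read-out: 2,6-dimethylmorpholin-4-yl in place of methylamino gives an at least 2.4-fold higher number from compound 2 to compound 3 (0.38 log units; beyond the scatter), and in place of cyclobutylamino it gives an at least 2.0-fold higher number from compound 1 to compound 3 (0.31 log units; beyond the scatter), whereas the earlier swap of methyl for cyclobutyl stayed within the scatter. The full size of both new steps stays unknown, since compound 3 sits at the limit of the measurement: the limit of > 50000 nM in this assay, at which 1 of the 3 values shown sits.

Going from methylamino to 2,6-dimethylmorpholin-4-yl adds heavy atoms and a six-membered ring, brings in a ring oxygen and removes the hydrogen-bond donor all at once, so the compounds shown cannot say which of these differences goes with the weaker result. As far as these compounds go, it remains open how a dimethylamino group, with no ring and no hydrogen-bond donor, or a morpholin-4-yl ring without the two methyl groups would read on this same carbonyl carbon.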